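Removing the Bromine from a Hydroxamic Acid HDAC6 Compound

The compounds below may be only part of what the source reports. "The series", "measured", "known", "first", "only" and "open" are said of these compounds alone.

Compound 1 `O=C(NO)c1ccc(NCc2nc(-c3ccc(Br)cc3)nn2-c2ccccc2)cc1` was tested in an assay on Sf9 cells for inhibition of protein deacetylase HDAC6 (Homo sapiens), read by fluorescence, with a stated time of 40 min, tested at 100 nM (a lower number here means less inhibition, a higher number more inhibition at the concentration tested (going by the name of the read-out)), and gave 54.7%. Among the three measured compounds this is the second highest number: compound 3 `Cc1ccc(-c2nc(CNc3ccc(C(=O)NO)cc3)n(-c3ccccc3)n2)s1` gives 79.7%, and compound 2 `Nc1ccccc1NC(=O)c1ccc(NCc2nc(-c3ccccc3)nn2-c2ccccc2)cc1` gives 5%. Compound 4 `O=C(NO)c1ccc(NCc2nc(-c3ccccc3)nn2-c2ccccc2)cc1` has not yet been measured. It differs from compound 1 in one place: hydrogen in place of bromo on an aromatic carbon.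

Among the measured compounds shown here, only one measured step changes a single place, and it is a number 25 percentage points higher from compound 1 to compound 3 (beyond the scatter), which exchanges the whole aryl group rather than a single substituent. For the measured compounds named here, no measured step removes a halogen alone, and compound 2 carries a different amide group besides its unsubstituted phenyl, so its low value does not speak directly to this change. Going by the values given here, with no step that bears directly on it, a small change is expected, if any, and a slight drop is thought somewhat more likely than a rise. The step of a number 9.7 percentage points lower from compound 1 to compound 4 (within the scatter) is therefore expected to stay modest. Compound 4 is estimated at 45%, within a range from 20% to 70%.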

Compound 4, a percentage reported as inhibition, at one concentration (the size of the read-out at that concentration, not a potency): 72.6%
Compound 4: the middle estimate sits 27.6 percentage points below what was measured, outside the stated range (above it).
By their numbers in this assay, from the lowest: compound 2; then compound 1; then compounds 4 and 3 (each within the scatter of the next).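

In this assay, among the compounds shown here, taking the bromo group off the ring gives a number 17.9 percentage points higher from compound 1 to compound 4 (beyond the scatter) and so shows that this place, para to a large group, is not indifferent to its substituent, which no earlier step could show. The unsubstituted phenyl also gives a number 7.1 percentage points lower from compound 3 to compound 4 (within the scatter), so the earlier gain of a number 25 percentage points higher from compound 1 to compound 3 (beyond the scatter) from exchanging the whole aryl group does not need the 5-methylthiophen-2-yl group, as removing bromo alone leaves compound 4 within the scatter of compound 3. The matched pair giving a number 67.6 percentage points higher from compound 2 to compound 4 (beyond the scatter) now ties the low value of compound 2 to its 2-aminophenyl amide rather than to its unsubstituted phenyl.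

Nothing available explains the effect of the bromo group. Going by these compounds, whether fluorine, chlorine, methyl or methoxy at this place would behave like bromo or like hydrogen remains open.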